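The compounds below may be only part of what the source reports. "The series", "measured", "known", "first", "only" and "open" are said of these compounds alone.

Compound 1 `N#Cc1ccccc1CN1C(=O)N(Cc2ccccc2)S(=O)(=O)n2cccc21`: > 318000 nM
Compound 2 `N#Cc1ccccc1CN1C(=O)N(Cc2cccc(F)c2)S(=O)(=O)n2cccc21`: > 305000 nM

In an ADME assay on MT4 cells (Homo sapiens) for cytotoxicity, read by MTT assay, with a stated time of 5 days (on this read-out lower numbers stand for higher toxicity in this test and higher numbers for lower toxicity in this test), compound 1 reaches only a limit, > 318000 nM. Compound 2 likewise gives only a limit, > 305000 nM. The step that the two limits leave unreadable from compound 1 to compound 2 therefore cannot be read, as both values sit at the limits the limit of > 305000 nM in this assay, at which 1 of the 2 values shown sits, and (the limit of > 318000 nM in this assay, at which 1 of the 2 values shown sits). Compound 3 `O=C1N(Cc2ccc(F)cc2)c2cccn2S(=O)(=O)N1Cc1ccccc1` differs from compound 1 by 4-fluorophenyl in place of 2-cyanophenyl on a saturated chain carbon bound to an amide-type nitrogen in a ring. No readable measured step bears on this change, so compound 3 is expected to remain at a limit in this assay, with an expected step of an at least 1.0-fold lower number from compound 1 to compound 3 (0.02 log units; that floor lies within the scatter) that stays within the scatter. The estimate for compound 3 is 300000 nM, with a range from 100000 nM to 600000 nM.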

Compound 3, half-maximal cytotoxic concentration: 150000 nM
Beside the measured number, compound 3's estimate is 2.0-fold (0.30 log units) above it; the measured number falls inside the stated range.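

In this assay, 4-fluorophenyl in place of 2-cyanophenyl on a saturated chain carbon bound to an amide-type nitrogen in a ring gives an at least 2.1-fold lower number from compound 1 to compound 3 (0.32 log units; beyond the scatter). Among the compounds shown here, this is the first readable change, as the step to compound 2 cannot be read, and it shows that this position can move the read-out towards higher toxicity in this test. Its true size stays open because compound 1 stands at a limit: the limit of > 318000 nM in this assay, at which 1 of the 3 values shown sits.

The compounds shown do not separate the loss of the nitrile from the entry of the fluorine. As far as these compounds go, how an unsubstituted benzyl or an aminomethyl group would read at this position remains open.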